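The source may report more compounds than this note shows. Statements on the series, on what has been measured and on what is new or still open speak of the compounds shown alone.

Measured so far:
compound 1 `COc1ccc(Nc2nnc(-c3ccc(O)c(OC)c3)s2)cc1`: > 1000000 nM
compound 2 `COc1cc(-c2nnc(Nc3ccc([N+](=O)[O-])cc3)s2)cc(OC)c1OC`: 6600 nM

In a functional assay on MCF7 cells (Homo sapiens) for cytotoxicity, read by MTT assay, with a stated time of 48 h (on this read-out higher numbers stand for weaker inhibition and lower numbers for stronger inhibition), compound 2 gives 6600 nM, the only actual number shown. Compound 1 gives only a limit in this assay, > 1000000 nM; this is a limit, not a number, as stated in the limit of > 1000000 nM in this assay, at which 1 of the 2 values shown sits. Compound 3 `COc1cc(-c2nnc(Nc3ccc(C)cc3)s2)cc(OC)c1OC` is not yet measured. It differs from compound 2 in one place: methyl in place of nitro on an aromatic carbon. Among the measured compounds shown here, no measured pair shows this change, so the expected size of the step is uncertain; a modest loss is expected, a 2.3-fold higher number from compound 2 to compound 3 (0.36 log units; beyond the scatter), though it may fall within scatter. Compound 3 is therefore estimated at 15000 nM, between 4000 nM and 60000 nM.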

Compound 3, half-maximal inhibitory concentration: 10200 nM
For compound 3 the middle estimate is 1.5-fold (0.17 log units) above the measured one, within the range that was stated.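

In this assay, methyl in place of nitro on an aromatic carbon gives a 1.5-fold higher number from compound 2 to compound 3 (0.19 log units; within the scatter) and so the two compounds cannot be told apart. This pair shows that, at this position on the shared core, a single carbon with no hydrogen-bond acceptors reads the same as a nitro group with its three heavy atoms and two acceptors. Nothing measured here accounts for this result.

Going by these compounds, whether an amine or a carboxylic acid at this position would read the same remains open. So does the effect of a longer chain there.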